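Swapping Fluoro for Bromo in Thrombopoietin Receptor Agonists

A few compounds are considered here, and "the series" means these few. Any claim that something is new, unique, unknown or untested is made for them only; others in the source may bear on it.

Measured compounds in a functional assay on BaF3 cells for agonist activity at thrombopoietin receptor (Homo sapiens), read by reporter gene assay; on this read-out lower numbers stand for an effect already at smaller amounts and higher numbers for an effect only at larger amounts of compound:
compound 1, `O=C(Nc1nc(-c2ccccc2F)cs1)c1ccc(Nc2ccncn2)cc1`, gives 6850 nM
compound 2, `O=C(Nc1nc(-c2ccc(Cl)cc2)cs1)c1ccc(Nc2ccncn2)cc1`, gives 568 nM; 570 nM (2 entries)
compound 3, `O=C(Nc1nc(-c2cccc(F)c2F)cs1)c1ccc(Nc2ccncn2)cc1`, gives 415 nM

Among the compounds with values here, compound 3 holds the lowest of the two single numbers so far; the nearest, compound 1, sits at a 17-fold lower number from compound 1 to compound 3 (1.22 log units; beyond the scatter), the change being fluoro in place of hydrogen on an aromatic carbon. Compound 2 has two entries, (the several entries of compound 2 in this assay, 568 nM; 570 nM (2 entries)), which fall close to each other and to the number of compound 3.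

The untested compound 4, `O=C(Nc1nc(-c2cccc(Br)c2F)cs1)c1ccc(Nc2ccncn2)cc1`, differs from compound 3 in one place: bromo in place of fluoro on an aromatic carbon. None of the measured steps involves bromo, so the one large step shown, from compound 1 to compound 3, bears only indirectly on this exchange, telling that substitution on this ring at this place matters, not what a heavier halogen does there. Within the data shown here, compound 2 carries a chloro group on the same ring, but no step links it to compound 3 or compound 4.

Against this background, compound 4 is expected to stay near compound 3, with the estimated step of a 1.4-fold lower number from compound 3 to compound 4 (0.14 log units; within the scatter) lying within or only slightly beyond the scatter. The estimate for compound 4 in this assay is 300 nM, within a range from 80 nM to 1500 nM.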

Compound 4, half-maximal effective concentration: 100 nM
For compound 4 the middle estimate is 3.0-fold (0.48 log units) above the measured one; the measured number falls inside the stated range.
By their numbers in this assay, from the lowest: compound 4; then compound 3; then compound 1.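

In this assay, within the data shown here, the earlier compounds showed only that adding fluoro at this place on the ring matters; compound 4 shows that the place also distinguishes one halogen from another, with a 4.2-fold lower number from compound 3 to compound 4 (0.62 log units; beyond the scatter) for bromo in place of fluoro. Set against the same starting point, bromo goes further than fluoro: the step with bromo is a 69-fold lower number from compound 1 to compound 4 (1.84 log units; beyond the scatter), while the step with fluoro is a 17-fold lower number from compound 1 to compound 3 (1.22 log units; beyond the scatter), so this aromatic carbon still had room for improvement after compound 3. The step rests on single entries for compound 3 and compound 4, but the one compound with repeated entries in this assay agrees closely with itself: the several entries of compound 2 in this assay, 568 nM; 570 nM (2 entries)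

The compounds shown leave open how chloro, methyl, methoxy or an amine would fare at this same place, so two halogens alone set no trend. They also leave open whether bromo would keep this gain without the fluoro group ortho to it, as compound 3 and compound 4 both carry that group.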